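The source may hold more compounds than are shown below. What is called first, only, known or untested is meant among the compounds shown, and "the series" means these compounds.

Working notes on the series. In a functional assay on WiDr cells (Homo sapiens) for inhibition, read by sulforhodamine B assay, with a stated time of 48 h (a lower number here means a stronger inhibitor of growth, a higher number a weaker inhibitor of growth), compound 1 `COC(=O)[C@@]1(C)CCC=C2[C@@H]1CC[C@@H](C)[C@]2(C)Cc1c(C)[nH]c2c(C)cccc12` gives 21000 nM. Compound 2 `COC(=O)[C@@]1(C)CCC=C2[C@@H]1CC[C@@H](C)[C@]2(C)Cc1c(C)[nH]c2c(Br)cccc12` differs from it in one place, (bromo in place of methyl on an aromatic carbon), and in this assay compound 2 gives 38000 nM, a step of a 1.8-fold higher number from compound 1 to compound 2 (0.26 log units; within the scatter). Compound 3 `COC(=O)[C@@]1(C)CC[C@@H]2C3=C1CC[C@@H](C)[C@]3(C)Cc1c2[nH]c2ccc(C)cc12`, built on a different core, gives 19000 nM in this assay; the difference between the core of compound 1 and the core of compound 3 is not broken down here, and the values of compound 1 and compound 3 lie within the scatter of one another, as do those of compound 3 and compound 2.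

Compound 4 `COC(=O)[C@@]1(C)CC[C@@H]2C3=C1CC[C@@H](C)[C@]3(C)Cc1c2[nH]c2ccc(Br)cc12` carries the same kind of change on the core of compound 3, (bromo in place of methyl on an aromatic carbon). The place is not the same: in compound 1 the ring is part of a fused or bridged system of two rings, ortho to a fused ring and meta to a fused ring, whereas in compound 3 it is part of a fused or bridged system of five rings, meta to a fused ring and para to a fused ring. From compound 3 the expected step is a 1.5-fold higher number from compound 3 to compound 4 (0.17 log units; within the scatter), resting on the earlier step of a 1.8-fold higher number from compound 1 to compound 2 (0.26 log units; within the scatter) and on the small size of that step. Compound 4 is therefore expected to give 28000 nM in this assay, estimated between 14000 nM and 60000 nM.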

Compound 4, concentration for 50% growth inhibition: 22000 nM
Compound 4: middle estimate off by 1.3-fold (0.10 log units), on the high side; measured number inside the range.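

In this assay, the exchange of methyl for bromo on an aromatic carbon of the second core gives a 1.2-fold higher number from compound 3 to compound 4 (0.06 log units; within the scatter). Set beside the earlier case, the two steps do not differ: the same change on two cores in this assay, a 1.8-fold higher number (0.26 log units; within the scatter) from compound 1 to compound 2 and a 1.2-fold higher number (0.06 log units; within the scatter) from compound 3 to compound 4, 1.6-fold (0.19 log units) apart, within the scatter of two such steps. The change therefore carries from one core to the other with no step beyond the scatter, but the core and the place on the ring differ together between the two pairs, so neither can be judged alone, and two small steps in one assay do not establish the same behaviour on any further core.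

The compounds shown leave open whether a group other than methyl or bromo at these places, such as an amine, a carboxylic acid or a longer chain, would give a step beyond the scatter on either core. Also open, going by these compounds, is whether the exchange of methyl for bromo would stay this small at another place on the aromatic ring.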